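The source may hold more compounds than are shown below. What is called first, only, known or untested is meant among the compounds shown, and "the series" means these compounds.

Compound 1 `O=C(Nc1cc(Sc2ncn[nH]2)c(O)c2ccccc12)c1cccc(Cl)c1` — in a functional assay on HCT-116 cells (Homo sapiens) for antiproliferative activity, read by MTT assay, with a stated time of 48 h (a higher number here means a weaker inhibitor, a lower number a stronger inhibitor), compound 1 gives > 100000 nM, which is a limit of the assay and not a number.
Compound 2 `O=C(/C=C/c1ccc(Cl)cc1)Nc1cc(Sc2ncn[nH]2)c(O)c2ccccc12` — in this assay compound 2 gives > 100000 nM, again a limit.

Within the data shown here, compound 2 therefore sits at the limit of > 100000 nM in this assay, at which 2 of the 2 values shown sit, and the only measured step, a step that the two limits leave unreadable from compound 1 to compound 2, cannot be read because the limit of > 100000 nM in this assay, at which 2 of the 2 values shown sit, hides both ends. Compound 3 `Cc1cccc(C(=O)Nc2cc(Sc3ncn[nH]3)c(O)c3ccccc23)c1` differs from compound 2 by 3-methylphenyl in place of 2-(4-chlorophenyl)ethenyl on a carbonyl carbon. With no readable step to draw on, no direction or size beyond the scatter can be foreseen, and another limit seems most likely. Compound 3 is expected at 150000 nM, between 30000 nM and 600000 nM. The expected step is a step that the limit leaves unreadable from compound 2 to compound 3.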

Compound 3, half-maximal inhibitory concentration: > 100000 nM
Compound 3: a limit, no number; the forecaster's own chance of this, stated with the estimate: 80%; the middle value does not contradict the limit.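

No new step can be read among compound 1, compound 2 and compound 3, because all three stop at the same limit of the assay: the limit of > 100000 nM in this assay, at which 3 of the 3 values shown sit. On these data alone, whether any group on the carbonyl carbon gives a readable number in this assay stays open.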